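Replacing the Phenyl Ring with a Pyridyl Ring

A few compounds are considered here, and "the series" means these few. Any claim that something is new, unique, unknown or untested is made for them only; others in the source may bear on it.

Measured so far:
Compound 1, `Cn1cc(/C=C2/C(=O)Nc3ccccc32)c2cc(Nc3nccc(-c4ccccc4)n3)ccc21`: 17300 nM
Compound 2, `COc1ccc(-c2ccnc(Nc3ccc4c(c3)c(/C=C3/C(=O)Nc5ccccc53)cn4C)n2)cc1`: > 100000 nM, which is a limit of the assay rather than a number
Compound 3, `Cn1cc(/C=C2/C(=O)Nc3ccccc32)c2cc(Nc3nccc(-c4ccc(C(F)(F)F)cc4)n3)ccc21`: 63900 nM

All three compounds share one core and differ only in what sits on the phenyl ring at its end. In a functional assay on PA-1 cells (Homo sapiens) for cytotoxicity, read by MTT assay, with a stated time of 48 h (a lower number here means a stronger inhibitor, a higher number a weaker inhibitor), compound 1 gives 17300 nM, the lowest of the two numbers read. Compound 3 carries trifluoromethyl in place of hydrogen on an aromatic carbon and shows a 3.7-fold higher number from compound 1 to compound 3 (0.57 log units; beyond the scatter). For compound 2 the assay reports only a limit, > 100000 nM. Between compound 1 and compound 2 this means an at least 5.7-fold higher number from compound 1 to compound 2 (0.76 log units; beyond the scatter), and between compound 2 and compound 3 an at least 1.5-fold lower number from compound 2 to compound 3 (0.19 log units; that floor lies within the scatter).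

Compound 4, `Cn1cc(/C=C2/C(=O)Nc3ccccc32)c2cc(Nc3nccc(-c4cccnc4)n3)ccc21`, has not yet been measured. It differs from compound 1 in this way: pyridin-3-yl in place of phenyl on an aromatic carbon. Both measured steps added a group to the phenyl ring and both gave a weaker inhibitor; neither exchanged a ring atom, so they bear on this change only loosely. A small loss or no step beyond the scatter is expected, that is a 1.4-fold higher number from compound 1 to compound 4 (0.16 log units; within the scatter). Compound 4 is therefore estimated at 25000 nM, with a range from 9000 nM to 70000 nM.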

Compound 4, half-maximal inhibitory concentration: 18100 nM
The estimate for compound 4 lay 1.4-fold (0.14 log units) above the measured number; the range from low to high includes it.
By their numbers in this assay, from the lowest: compounds 1 and 4 (each within the scatter of the next); then compound 3. At a limit, above all of these: compound 2.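

In this assay, exchanging one carbon of the end ring for nitrogen turns phenyl into pyridin-3-yl and brings one hydrogen-bond acceptor, yet it gives a 1.0-fold higher number from compound 1 to compound 4 (0.02 log units; within the scatter), so unlike the two groups added to the phenyl ring, this change of the ring itself leaves the number within the scatter. Set against 4-(trifluoromethyl)phenyl, pyridin-3-yl gives a 3.5-fold lower number from compound 3 to compound 4 (0.55 log units; beyond the scatter), which places the cost in that series on the added group rather than on the nature of the end ring, as far as these four compounds go. Set against 4-methoxyphenyl, pyridin-3-yl gives an at least 5.5-fold lower number from compound 2 to compound 4 (0.74 log units; beyond the scatter), but that size is only a floor, as compound 2 has a limit of the assay and not a number: the limit of > 100000 nM in this assay, at which 1 of the 4 values shown sits.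

The compounds shown do not tell whether the ring nitrogen would be tolerated elsewhere in the end ring, or whether a smaller group such as fluorine, or an amine or a carboxylic acid, on that ring would lower the number. They also give no cause for any of these steps, since they show one cell assay and no measured property of the groups.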